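Trifluoromethyl additions on two dienone cores

The source may report more compounds than this note shows. Statements on the series, on what has been measured and on what is new or still open speak of the compounds shown alone.

Measured so far:
compound 1, `CC1=CCCC(C)(C)C1/C=C/C(=O)/C=C/c1ccccc1F`, 9400 nM
compound 2, `CC1=CCCC(C)(C)C1/C=C/C(=O)/C=C/c1cc(C(F)(F)F)ccc1F`, 3500 nM
compound 3, `CC1=C(/C=C/C(=O)/C=C/c2ccccc2F)C(C)(C)CCC1O`, 3300 nM

All three numbers come from a functional assay on CWR22R cells (Homo sapiens) for cytotoxicity, read by MTT assay, with a stated time of 72 h; on this read-out lower numbers stand for stronger inhibition and higher numbers for weaker inhibition. Compound 1 and compound 2 share one core and differ by trifluoromethyl in place of hydrogen on an aromatic carbon; that change gave a 2.7-fold lower number from compound 1 to compound 2 (0.43 log units; beyond the scatter). Compound 3 rests on another core; the difference between the two cores is not broken down here. The number of compound 3 and the number of compound 2 lie within the scatter of each other, so no order between them is claimed; against compound 1 the number of compound 3 is lower by more than the scatter.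

Compound 4, `CC1=C(/C=C/C(=O)/C=C/c2c(F)cccc2C(F)(F)F)C(C)(C)CCC1O`, is not yet measured in this assay. It differs from compound 3 by trifluoromethyl in place of hydrogen on an aromatic carbon. Going by the values given here, this is the same kind of change as the one from compound 1 to compound 2, but the surroundings are not the same: in compound 2 the entering group sits meta to a large group and para to a fluoro group, whereas in compound 4 it sits ortho to a large group and meta to a fluoro group. A step of the same direction is expected because the earlier step of a 2.7-fold lower number from compound 1 to compound 2 (0.43 log units; beyond the scatter) was modest and beyond the scatter, yet the changed surroundings leave its size less certain. For compound 4 the expected step is a 2.1-fold lower number from compound 3 to compound 4 (0.31 log units; beyond the scatter). Compound 4 is estimated at 1600 nM in this assay, with a likely range from 600 nM to 4000 nM.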

Compound 4, half-maximal inhibitory concentration: 8900 nM
Estimate against measurement, compound 4: 5.6-fold (0.75 log units) below; measured number outside the range, above it.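

In this assay, trifluoromethyl in place of hydrogen on an aromatic carbon gave a 2.7-fold higher number from compound 3 to compound 4 (0.43 log units; beyond the scatter), so the direction of the change did not carry over from the core of compound 1 to the core of compound 3: the same change on two cores in this assay, a 2.7-fold lower number (0.43 log units; beyond the scatter) from compound 1 to compound 2 and a 2.7-fold higher number (0.43 log units; beyond the scatter) from compound 3 to compound 4, 7.2-fold (0.86 log units) apart, beyond the scatter of two such steps. The earlier step therefore cannot serve as a guide to the direction of this change on the core of compound 3, at least for the placement seen in compound 4. Going by these compounds alone, this does not show that the core alone decides the outcome, as the entering group in compound 4 sits ortho to a large group and meta to a fluoro group, a different place from the one it holds in compound 2, so core and placement change together across these two pairs, and two pairs give no general rule.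

The compounds shown leave open whether the opposite direction follows the core or the placement, a question that trifluoromethyl placed as in compound 2 on the core of compound 3 would address. Also open, as far as these compounds go, is whether a chloro group or a nitrile at the place trifluoromethyl holds in compound 4 would move the number in the same direction.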